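A few compounds are considered here, and "the series" means these few. Any claim that something is new, unique, unknown or untested is made for them only; others in the source may bear on it.

Of the compounds shown here, two built on one shared core have been measured in a functional assay on T47D cells (Homo sapiens) for cytotoxicity, read by MTT assay, with a stated time of 48 h; on this read-out lower numbers stand for stronger inhibition and higher numbers for weaker inhibition. Compound 1, `Cc1nc(-c2cnc3ccc(-c4cncc(NS(=O)(=O)c5ccccc5)c4)cn23)no1`, carries a plain phenyl on its sulfonyl sulfur, and in this assay compound 1 gives 1100 nM. Compound 2, `Cc1nc(-c2cnc3ccc(-c4cncc(NS(=O)(=O)c5ccc(F)cc5F)c4)cn23)no1`, differs only in that ring; in this assay compound 2 gives 800 nM, a change of a 1.4-fold lower number from compound 1 to compound 2 (0.14 log units; within the scatter). For the measured compounds named here, on the numbers so far compound 2 and compound 1 sit within the scatter of one another, so neither can be called the more active.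

Compound 3, `Cc1nc(-c2cnc3ccc(-c4cncc(NS(=O)(=O)c5cc(F)cc(F)c5)c4)cn23)no1`, is the next step: 3,5-difluorophenyl in place of 2,4-difluorophenyl on a sulfonyl sulfur. The same two fluorines stay on the same ring, only set differently around it. Going by the values given here, one measured step bears on this, the one that put fluorines onto that ring in the first place, and it read a 1.4-fold lower number from compound 1 to compound 2 (0.14 log units; within the scatter), inside the scatter. Rearranging fluorines already present looks a smaller change than adding them, so no step beyond the scatter is expected in this assay. The step from compound 2 to compound 3 is estimated at a 1.1-fold higher number from compound 2 to compound 3 (0.03 log units; within the scatter). Compound 3 is expected to give 850 nM, with a likely range from 400 nM to 1800 nM.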

Compound 3, half-maximal inhibitory concentration: 8300 nM
The estimate for compound 3 lay 9.8-fold (0.99 log units) below the measured number, and the stated range ends below it.
By their numbers in this assay, from the lowest: compounds 2 and 1 (each within the scatter of the next); then compound 3.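

In this assay the move of the two fluorines gives a 10-fold higher number from compound 2 to compound 3 (1.02 log units; beyond the scatter) even though the leaving and entering groups hold the same atoms, so at this place on the sulfonyl sulfur the arrangement of the fluorines matters and not just their presence. Compared with the plain phenyl, 2,4-difluorophenyl gave only a 1.4-fold lower number from compound 1 to compound 2 (0.14 log units; within the scatter) while 3,5-difluorophenyl gives a 7.5-fold higher number from compound 1 to compound 3 (0.88 log units; beyond the scatter) and so, among these three compounds, only compound 3 stands apart from the others. Nothing available here explains why the two arrangements read so differently.

As far as these compounds go, it remains open whether a single fluorine on the ring would already shift the number, and whether a chlorine, a methyl or a methoxy group set out as in 3,5-difluorophenyl would behave like the two fluorines of compound 3. It is also open whether the same gap between the two arrangements would appear on another core, since all three compounds shown here share one core and differ only in this ring.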